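This account rests on a few compounds, and the source may have more. Where it says the series, first, only, none or still open, it means among the compounds named here.

Compound 1 `COc1cc2ncnc(-n3nc(C4CCCCC4)nc3N)c2cc1OC` gives only a limit of the assay in an assay on MCF7 cells for inhibition of Serine-protein kinase ATM (Homo sapiens), read by immunofluorescence, with a stated time of 1 h (a lower number here means a stronger inhibitor, a higher number a weaker inhibitor), namely > 40000 nM. For the measured compounds named here, that is the single value resting at the limit of > 40000 nM in this assay, at which 1 of the 3 values shown sits, among the three values shown. Compound 2 `COc1cc2ncnc(-n3nc(-c4ccccn4)nc3N)c2cc1OCCCN1CC(C)OC(C)C1` gives 1600 nM in this assay, and compound 3 `CCN(CC)C(=O)COc1cc2c(-n3nc(-c4ccccn4)nc3N)ncnc2cc1OC` gives 5300 nM, the highest of the two numbers. Going by the values given here, the one measured step that bears on the position in question is a 3.3-fold higher number from compound 2 to compound 3 (0.52 log units; beyond the scatter), a change at the same chain carbon that is now altered again.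

Compound 4 `COc1cc2ncnc(-n3nc(-c4ccccn4)nc3N)c2cc1OCCCNC(=O)OC(C)C` has not yet been measured. It differs from compound 3 by 2-((isopropoxycarbonyl)amino)ethyl in place of diethylcarbamoyl on a saturated chain carbon bound to an oxygen on an aromatic ring. The step from compound 2 to compound 3 showed that a swap at this position can move the number by a modest amount, and compound 4 returns to a three-carbon chain on the ring oxygen, as in compound 2, though with a carbamate in place of the amine. The expected step is therefore a 1.8-fold lower number from compound 3 to compound 4 (0.25 log units; within the scatter), a modest lowering that may not clear the scatter. Compound 4 is estimated at 3000 nM, within 1000 nM to 9000 nM.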

Compound 4, half-maximal inhibitory concentration: 1000 nM
Compound 4: middle estimate off by 3.0-fold (0.48 log units), on the high side, within the range that was stated.
By their numbers in this assay, from the lowest: compounds 4 and 2 (each within the scatter of the next); then compound 3. At a limit, above all of these: compound 1.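

In this assay, putting 2-((isopropoxycarbonyl)amino)ethyl in place of diethylcarbamoyl gives a 5.3-fold lower number from compound 3 to compound 4 (0.72 log units; beyond the scatter), so this position responds to a change of both chain and end group. The earlier step showed only a loss on leaving the chain that carries the 2,6-dimethylmorpholin-4-yl group, whereas the new comparison, a 1.6-fold lower number from compound 2 to compound 4 (0.20 log units; within the scatter), shows that (isopropoxycarbonyl)amino and that ring-bearing group are not separated on the propyl chain. Two quite different chain ends thus read alike here, and compound 3 alone stands apart.

The step to compound 4 alters chain length and end group together, so the compounds shown cannot divide the effect between them. A propyl chain ending in diethylcarbamoyl, a carboxylic acid or a primary amine remains open, and nothing shown gives a cause for either step.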